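Methyl in place of cyano on selenium: projected step

The source may hold more compounds than are shown below. What is called first, only, known or untested is meant among the compounds shown, and "the series" means these compounds.

compound 1 `COc1ccc(N(C)c2nc(C)nc3ccccc23)cc1C(=O)OCCCC[Se]C#N`: 1020 nM
compound 2 `COc1ccc(N(C)c2nc(C)nc3ccccc23)cc1[Se]C#N`: 47 nM

Two compounds of the shared core have numbers in a functional assay on RKO cells (Homo sapiens) for inhibition, read by MTT assay, with a stated time of 48 h; on this read-out lower numbers stand for stronger inhibition and higher numbers for weaker inhibition. Among the compounds with values here, compound 2 stands lowest of the two, and the single measured step, a 22-fold lower number from compound 1 to compound 2 (1.34 log units; beyond the scatter), separates it from compound 1 by a large margin, well beyond the scatter.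

Compound 3 `COc1ccc(N(C)c2nc(C)nc3ccccc23)cc1[Se]C` differs from compound 2 in one place: methyl in place of cyano on a selenium. Within the data shown here, no measured step touches the group on the selenium; the one step recorded exchanges what carries the selenium rather than what sits on it, so it gives no direct guide to the present change. The expectation for compound 3 is therefore uncertain in size, though a rise in the number, beyond the scatter yet smaller than the measured step, is expected, with a 6.4-fold higher number from compound 2 to compound 3 (0.81 log units; beyond the scatter) as the working figure. Compound 3 is thus estimated at 300 nM, in a range from 80 nM to 1500 nM.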

Compound 3, half-maximal inhibitory concentration: 11 nM
Compound 3: the middle estimate sits 27-fold (1.44 log units) above what was measured, outside the stated range (below it).
By their numbers in this assay, from the lowest: compound 3; then compound 2; then compound 1.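

In this assay, the nitrile on the selenium is not required for a low number: with the selenium carried by an aromatic carbon, methyl in place of cyano gives a 4.3-fold lower number from compound 2 to compound 3 (0.63 log units; beyond the scatter). Against the longer ester-linked group of compound 1, the methyl on selenium gives a 93-fold lower number from compound 1 to compound 3 (1.97 log units; beyond the scatter), a wider gap than the nitrile-bearing compound 2 showed, and compound 3 has the lowest number of the three. No data at hand bear on why the step runs in this direction.

Still open, from the compounds shown here alone, is whether an ethyl group or a longer chain on the selenium would keep the number of compound 3. Also open, going by these compounds, is whether the selenium itself matters, which a sulfur atom carrying the same methyl would test.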